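A few compounds are considered here, and "the series" means these few. Any claim that something is new, unique, unknown or untested is made for them only; others in the source may bear on it.

Measured compounds:
compound 1 `COc1ccc(OCCOc2ccc3[nH]c(=O)n(C(C)C)c3c2)cc1` — "not determined" (no result reported)
compound 2 `CCn1c(=O)[nH]c2ccc(OCCOc3ccc(Cl)cc3)cc21` — "not determined" (no result reported)
compound 3 `CCn1c(=O)[nH]c2ccc(OCCOc3ccc(C(C)C)cc3)cc21` — > 500000 nM

In an assay on cells for inhibition of Amine oxidase [flavin-containing] A (Homo sapiens), read by fluorescence, with stated times of 30 min and 15 min (a lower number here means a stronger inhibitor, a higher number a weaker inhibitor), compound 1 gives "not determined" (no result reported). Compound 2 likewise gives "not determined" (no result reported) in this assay. For the measured compounds named here, compound 3 therefore stands alone with an actual entry, and that entry is a limit of this assay rather than a number: compound 3 gives > 500000 nM, the one value sitting at the limit of > 500000 nM in this assay, at which 1 of the 3 values shown sits. Going by the values given here, no step between two measured compounds exists here.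

Compound 4 `CC(C)c1ccc(OCCOc2ccc3[nH]c(=O)n(C(C)C)c3c2)cc1` differs from compound 3 by methyl in place of hydrogen on a saturated chain carbon bound to an aromatic nitrogen and a saturated chain carbon. With only a limit for compound 3 to start from, no step beyond the usual scatter is expected from compound 3 to compound 4, and the estimate is a number no higher from compound 3 to compound 4 (the limit leaves the size open). Compound 4 is thus expected to give about 500000 nM, between 100000 nM and 2000000 nM, most likely again as a limit.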

Compound 4, half-maximal inhibitory concentration: > 500000 nM
Compound 4: no number, only a limit (the forecaster's own chance of this, stated with the estimate: 80%); the middle value sits exactly at the limit.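

No step can be read between compound 3 and compound 4, as each gives only a limit and not a number. The compounds shown leave open whether any structure in this series reaches a measurable value in this assay.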